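The source may hold more compounds than are shown below. What is called first, only, known or untested is meant among the compounds shown, and "the series" means these compounds.

Of the compounds shown here, three built on one shared core have so far been measured in a physicochemical assay for solubility, read by HPLC, in phosphate buffer, with a stated time of 4 h, at pH 7.4; on this read-out lower numbers stand for lower solubility and higher numbers for higher solubility. Compound 1 `COCCOC(=O)c1cc(N)c(Nc2ccc(C#N)cc2)cc1Oc1c(C)cc(/C=C/C#N)cc1C` gives 0.77 ug/mL, compound 2 `COC(=O)c1cc(N)c(Nc2ccc(C#N)cc2)cc1Oc1c(C)cc(/C=C/C#N)cc1C` gives 1.21 ug/mL, and compound 3 `Cc1cc(/C=C/C#N)cc(C)c1Oc1cc(Nc2ccc(C#N)cc2)c(N)cc1C(=O)OCCC#N` gives 0.36 ug/mL, the lowest of the three numbers. Two steps lead to it: a 2.1-fold lower number from compound 1 to compound 3 (0.33 log units; beyond the scatter) and a 3.4-fold lower number from compound 2 to compound 3 (0.53 log units; beyond the scatter); between the other pair, a 1.6-fold higher number from compound 1 to compound 2 (0.20 log units; within the scatter). Compound 4 `Cc1cc(/C=C/C#N)cc(C)c1Oc1cc(Nc2ccc(C#N)cc2)c(N)cc1C(=O)NCCC(F)F` differs from compound 3 in a single place: (3,3-difluoropropyl)amino in place of 2-cyanoethoxy on a carbonyl carbon. Among the measured compounds shown here, no measured step bears directly on this, since each of them alters only the chain on a saturated carbon bound to an oxygen next to a carbonyl group, and all stayed modest. A modest upward step in this assay is therefore expected, a 2.8-fold higher number from compound 3 to compound 4 (0.44 log units; beyond the scatter). Compound 4 is estimated at 1 ug/mL, between 0.3 ug/mL and 3 ug/mL.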

Compound 4, solubility: 6.59 ug/mL
Compound 4: the middle estimate sits 6.6-fold (0.82 log units) below what was measured; measured number outside the range, above it.
By their numbers in this assay, from the lowest: compound 3; then compounds 1 and 2 (each within the scatter of the next); then compound 4.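

Among the compounds shown here, replacing the oxygen-linked chain on the carbonyl carbon with (3,3-difluoropropyl)amino gives the largest step seen in this assay so far (an 18-fold higher number from compound 3 to compound 4 (1.26 log units; beyond the scatter)). The number also rises against the other two oxygen-linked compounds (a 5.4-fold higher number from compound 2 to compound 4 (0.74 log units; beyond the scatter); an 8.6-fold higher number from compound 1 to compound 4 (0.93 log units; beyond the scatter)), so this change has a far larger effect on the read-out than the earlier chain changes did. No measurement shown explains the rise.

This single change replaces both the linking atom and the chain, so their contributions cannot be separated. A propylamino group or a 3,3-difluoropropoxy group on the same carbonyl carbon would address that question.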